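Working notes: dimethylamino in place of methyl

The source may report more compounds than this note shows. Statements on the series, on what has been measured and on what is new or still open speak of the compounds shown alone.

The compounds share one core and differ in a single group on an aromatic carbon. In a functional assay on L1210 cells (Mus musculus) for inhibition (a higher number here means a weaker inhibitor, a lower number a stronger inhibitor), compound 1 `O=C1/C(=C/c2ccc(F)cc2)CCc2ccccc21` gives 49300 nM, compound 2 `O=C1/C(=C/c2ccc(Br)cc2)CCc2ccccc21` gives 202000 nM, and compound 3 `Cc1ccc(/C=C2\CCc3ccccc3C2=O)cc1` gives 161000 nM. Compound 3 cannot be separated from compound 2, since the data show a 1.3-fold lower number from compound 2 to compound 3 (0.10 log units; within the scatter), within the scatter. Against the fluoro compound the data show a 3.3-fold higher number from compound 1 to compound 3 (0.51 log units; beyond the scatter), beyond the scatter.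

Compound 4 `CN(C)c1ccc(/C=C2\CCc3ccccc3C2=O)cc1` differs from compound 3 by dimethylamino in place of methyl on an aromatic carbon, para to a large group. For the measured compounds named here, no measured compound carries dimethylamino, so the closest guide is the other group swaps. These are a 4.1-fold higher number from compound 1 to compound 2 (0.61 log units; beyond the scatter) and a 3.3-fold higher number from compound 1 to compound 3 (0.51 log units; beyond the scatter), both modest, and a 1.3-fold lower number from compound 2 to compound 3 (0.10 log units; within the scatter), within the scatter. No clear direction follows from them, so no step beyond the scatter is expected in this assay. The expected change is a 1.2-fold lower number from compound 3 to compound 4 (0.09 log units; within the scatter). For compound 4 the estimated value is 130000 nM, with an expected range of 50000 nM to 320000 nM.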

Compound 4, half-maximal inhibitory concentration: 17500 nM
Beside the measured number, compound 4's estimate is 7.4-fold (0.87 log units) above it, outside the stated range (below it).
By their numbers in this assay, from the lowest: compound 4; then compound 1; then compounds 3 and 2 (each within the scatter of the next).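

With dimethylamino on this aromatic carbon, para to a large group, the number in this assay falls well below those of the methyl and bromo compounds (a 9.2-fold lower number from compound 3 to compound 4 (0.96 log units; beyond the scatter); a 12-fold lower number from compound 2 to compound 4 (1.06 log units; beyond the scatter)), and the second of these steps is large. It also falls below the fluoro compound (a 2.8-fold lower number from compound 1 to compound 4 (0.45 log units; beyond the scatter)), so compound 4 is the strongest inhibitor of the four, and this position can move the number downward as well as upward from fluoro. Nothing at hand accounts for this change.

From the compounds shown here alone, the lower number rests on compound 4 alone, so it remains open whether it belongs to dimethylamino specifically or extends to other nitrogen groups. A primary amine, a morpholine or a methoxy group at this position would test that, and a carboxylic acid would show how far the trend holds.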